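This account rests on a few compounds, and the source may have more. Where it says the series, first, only, none or still open, it means among the compounds named here.

Compounds measured in an ADME assay for permeability, using PAMPA, with a stated time of 30 min, at pH 7.4; a higher number here means that the compound crosses the layer faster, a lower number that the compound crosses the layer more slowly:

Compound 1 `FC(F)(F)c1ccc(-c2ccc3c(NCCCNCc4ccco4)ccnc3c2)cc1` gives 237 10^-6 cm/s.
Compound 2 `COc1ccccc1Oc1ccc2c(NCCCNCc3ccco3)ccnc2c1` gives 317 10^-6 cm/s.
Compound 3 `COc1ccc(Oc2ccc3c(NCCCNCc4ccco4)ccnc3c2)cc1` gives 317 10^-6 cm/s.

Compound 2 stands level with compound 3 at the digits reported, and together these two hold the highest of the three numbers, but the step of a 1.3-fold higher number from compound 1 to compound 2 (0.13 log units; within the scatter) shows that the gap to compound 1 is within the scatter; likewise a 1.3-fold higher number from compound 1 to compound 3 (0.13 log units; within the scatter) and no change at the digits printed from compound 2 to compound 3 (within the scatter) are within the scatter, so the three measured compounds are not separated in this assay.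

Compound 4 `COc1ccc(F)cc1CNCCCNc1ccnc2cc(Oc3ccccc3OC)ccc12` is not yet measured. It differs from compound 2 in one place: 5-fluoro-2-methoxyphenyl in place of furan-2-yl on a saturated chain carbon bound to an amine nitrogen

For the measured compounds named here, none of the measured steps touches this position. The three steps seen so far all vary the group on the aromatic carbon of the shared core, or the aryl on the oxygen attached to it, and every one of them stayed within the scatter. Going by the values given here, there is therefore no measured step that bears directly on the change from compound 2 to compound 4, and nothing points to a shift beyond the scatter in either direction.

Compound 4 is therefore expected to give about 300 10^-6 cm/s, with a range of 170 10^-6 cm/s to 480 10^-6 cm/s. The expected step is a 1.1-fold lower number from compound 2 to compound 4 (0.02 log units; within the scatter), which is no more than the usual scatter.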

Compound 4, apparent permeability: 317 10^-6 cm/s
Compound 4: middle estimate off by 1.1-fold (0.02 log units), on the low side, within the range that was stated.
By their numbers in this assay, from the lowest: compounds 1, 2, 3 and 4 (each within the scatter of the next).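

For the compounds shown here, this is the first step at the saturated chain carbon bound to an amine nitrogen; all the earlier steps lay on the aromatic carbon of the shared core or on the oxygen attached there. In this assay the replacement of furan-2-yl, a five-membered aromatic ring with 5 heavy atoms, by 5-fluoro-2-methoxyphenyl, a six-membered aromatic ring of carbon only with 9 heavy atoms, gives no change at the digits printed from compound 2 to compound 4 (within the scatter) and so shows that this one exchange of aromatic groups, made on compound 2, does not separate the two compounds in this read-out. No measurement at hand offers an explanation for this outcome.

Whether the fluoro and methoxy groups of the new ring each matter cannot be told from this single exchange, and a plain benzyl or a 2-methoxybenzyl group would be needed to separate them. On these data alone, it also remains open whether the same indifference would hold for a non-aromatic group at this place, such as a cyclohexyl ring, a morpholine-bearing chain or a carboxylic acid, or for the same exchange on the core of compound 1.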